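Removing One Methoxy Group: Expected Cytotoxicity of Compound 3

The source may report more compounds than this note shows. Statements on the series, on what has been measured and on what is new or still open speak of the compounds shown alone.

Measured compounds:
compound 1 `COc1cc(-c2cc(/C=C/C(=O)c3ccc(N)cc3)[nH]n2)cc(OC)c1OC`: -85%
compound 2 `COc1cc(-c2cc(/C=C/C(=O)c3ccc(F)c(F)c3)[nH]n2)cc(OC)c1OC`: -64%

In a functional assay on SK-MEL-2 cells (Homo sapiens) for cytotoxicity, read by sulforhodamine B assay, with a stated time of 48 h, tested at 100 uM (on this read-out lower numbers stand for a stronger effect and higher numbers for a weaker effect at the one concentration tested), compound 1 gives -85%, the lowest of the two numbers, and compound 2 gives -64%. The step of a number 21 percentage points higher from compound 1 to compound 2 (beyond the scatter) is modest but beyond the scatter, and it concerns only the group on the carbonyl carbon. Compound 3 `COc1ccc(-c2cc(/C=C/C(=O)c3ccc(N)cc3)[nH]n2)cc1OC` differs from compound 1 by hydrogen in place of methoxy on an aromatic carbon. Among the compounds with values here, no measured step touches this position, so nothing measured bears directly on the change. Compound 3 is therefore estimated at -75%, with a range from -95% to -40%. This corresponds to an expected step of a number 10 percentage points higher from compound 1 to compound 3 (within the scatter), within the scatter.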

Compound 3, a percentage reported as activity, at one concentration (the size of the read-out at that concentration, not a potency): -86%
Estimate against measurement, compound 3: 11 percentage points above, and the stated range covers the measured number.
By their numbers in this assay, from the lowest: compounds 3 and 1 (each within the scatter of the next); then compound 2.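

In this assay, hydrogen in place of methoxy on this aromatic carbon gives a number 1 percentage points lower from compound 1 to compound 3 (within the scatter) and so leaves the read-out unchanged within the usual scatter. With 4-aminophenyl on the carbonyl carbon, this methoxy group is therefore not needed for the effect seen at the one concentration tested. Nothing available explains this tolerance. As far as these compounds go, whether ethoxy or chlorine on this carbon would give the same result remains open. So does whether removing this methoxy group would matter with 3,4-difluorophenyl on the carbonyl carbon.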